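This account rests on a few compounds, and the source may have more. Where it says the series, first, only, none or still open, it means among the compounds named here.

Compound 1, `CC(C)=CC[C@@H](OC(=O)CCO)C1=CC(=O)c2c(O)ccc(O)c2C1=O`, gives 55300 nM in a functional assay on DU-145 cells (Homo sapiens) for cytotoxicity, read by MTT assay; on this read-out higher numbers stand for weaker inhibition and lower numbers for stronger inhibition.
Compound 2, `CC(=O)OCCO[C@H](CC=C(C)C)C1=CC(=O)c2c(O)ccc(O)c2C1=O`, gives 15500 nM in this assay.
Compound 3, `CCC(O)CO[C@H](CC=C(C)C)C1=CC(=O)c2c(O)ccc(O)c2C1=O`, gives 16400 nM in this assay.

Compound 2 holds the lowest of the three numbers, though compound 3 sits within the scatter of it; only compound 1 stands apart, by a 3.6-fold lower number from compound 1 to compound 2 (0.55 log units; beyond the scatter). Compound 4, `CCCCC(C)(O)CC(=O)O[C@H](CC=C(C)C)C1=CC(=O)c2c(O)ccc(O)c2C1=O`, differs from compound 2 in one place: (2-hydroxy-2-methylhexyl)carbonyl in place of 2-acetoxyethyl on an oxygen on a saturated carbon. Like compound 1, compound 4 carries its side group through a carbonyl, so the step from compound 1 to compound 2, a 3.6-fold lower number from compound 1 to compound 2 (0.55 log units; beyond the scatter), is the closest guide, and the parallel step a 3.4-fold lower number from compound 1 to compound 3 (0.53 log units; beyond the scatter) points the same way. Reversing that direction, a modestly higher number is expected for compound 4, estimated at 40000 nM (range 15000 nM to 110000 nM), a step of a 2.6-fold higher number from compound 2 to compound 4 (0.41 log units; beyond the scatter).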

Compound 4, half-maximal inhibitory concentration: 76500 nM
Compound 4: the middle estimate sits 1.9-fold (0.28 log units) below what was measured; measured number inside the range.
By their numbers in this assay, from the lowest: compounds 2 and 3 (each within the scatter of the next); then compounds 1 and 4 (each within the scatter of the next).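

In this assay, at this oxygen on a saturated carbon, a 4.9-fold higher number from compound 2 to compound 4 (0.69 log units; beyond the scatter) and a 4.7-fold higher number from compound 3 to compound 4 (0.67 log units; beyond the scatter) show that (2-hydroxy-2-methylhexyl)carbonyl does not retain the level of either group without a carbonyl at that oxygen. Enlarging the carbonyl-linked side group changes little: 1-hydroxy-1-methylpentyl in place of hydroxymethyl gives a 1.4-fold higher number from compound 1 to compound 4 (0.14 log units; within the scatter) and stays within the scatter. Both carbonyl-linked compounds now stand apart from compounds 2 and 3, and no compound shown goes against this split.

On these data alone, whether a side group carrying an amine or a carboxylic acid at this oxygen would follow the split remains open. Nothing available gives a reason for the split.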